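The source may report more compounds than this note shows. Statements on the series, on what has been measured and on what is new or still open speak of the compounds shown alone.

Two compounds of this series carry numbers in a functional assay on NCI-H522 cells (Homo sapiens) for inhibition, read by sulforhodamine B assay, with a stated time of 48 h; a higher number here means a weaker inhibitor of growth, a lower number a stronger inhibitor of growth. Compound 1 `COc1cc(C)cc(-c2nn(CC#N)cc2-c2ccc(-c3cccc(C(C)=O)c3)nc2)c1` gives 1640 nM. Compound 2 `Cc1cc(O)cc(-c2nn(CC#N)cc2-c2ccnc(-c3ccc(Oc4ccccc4)cc3)c2)c1` gives 2720 nM; the two values lie within the scatter of each other, so no order between them is read from them. Compound 3 `Cc1cc(O)cc(-c2nn(CC#N)cc2-c2ccnc(-c3ccc(N(C)C)cc3)c2)c1` differs from compound 2 in one place: dimethylamino in place of phenoxy on an aromatic carbon. Going by the values given here, no measured pair covers a change of this kind, so the step is expected to stay within the scatter, a 1.1-fold lower number from compound 2 to compound 3 (0.04 log units; within the scatter), with no direction assigned. For compound 3 the expected value is 2500 nM, in a range from 800 nM to 8000 nM.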

Compound 3, concentration for 50% growth inhibition: 1930 nM
For compound 3 the middle estimate is 1.3-fold (0.11 log units) above the measured one; the range from low to high includes it.
By their numbers in this assay, from the lowest: compounds 1, 3 and 2 (each within the scatter of the next).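

Dimethylamino in place of phenoxy on an aromatic carbon, para to a large group, gives the only single-place step in the series: in this assay, a 1.4-fold lower number from compound 2 to compound 3 (0.15 log units; within the scatter). Seven heavy atoms and a carbon-only aromatic ring leave, three heavy atoms and no ring enter, and the step stays within the scatter, so this assay does not separate the two groups at this position. Nothing measured here offers an account of this result.

On these data alone, whether a primary amine or a carboxylic acid at this position would move the number beyond the scatter stays open. Which groups on the shared core, if any, govern the growth inhibition also stays open.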